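A few compounds are considered here, and "the series" means these few. Any claim that something is new, unique, unknown or untested is made for them only; others in the source may bear on it.

The compounds share one core, shown for compound 1 `O=C1c2ccc(Cl)cc2CN1c1cccnc1`. In an assay on cells for inhibition of cytochrome P450 11B2, mitochondrial (Homo sapiens), read by HTRF (a lower number here means a stronger inhibitor, a higher number a weaker inhibitor), compound 1 gives 179 nM. Compound 2 `O=C1c2ccccc2CN1c1cccnc1` carries hydrogen where compound 1 carries chloro, and in this assay compound 2 gives 1120 nM; the measured step is a 6.3-fold higher number from compound 1 to compound 2 (0.80 log units; beyond the scatter). Compound 3 `Cc1ccc(C(=O)Nc2cccnc2)cc1` gives > 3000 nM in this assay, which is a limit of the assay rather than a number (the limit of > 3000 nM in this assay, at which 1 of the 3 values shown sits). Among the numbers shown, compound 2 stands highest, with compound 1 as its nearest neighbour at a clearly lower value.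

Compound 4 `N#Cc1ccc2c(c1)CN(c1cccnc1)C2=O` differs from compound 2 in a single respect: cyano in place of hydrogen on an aromatic carbon. For the measured compounds named here, the one measured step that bears on this place is a 6.3-fold higher number from compound 1 to compound 2 (0.80 log units; beyond the scatter), where removing the chloro group from the same aromatic carbon raised the number by a modest but clear margin. A cyano group entering at that place is therefore expected to move the result in this assay in the opposite direction, lowering the number by a step of comparable size, so the expected step is a 7.5-fold lower number from compound 2 to compound 4 (0.87 log units; beyond the scatter). Compound 4 is accordingly estimated to give about 150 nM in this assay, within a range from 40 nM to 600 nM.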

Compound 4, half-maximal inhibitory concentration: 232 nM
Compound 4: the middle estimate sits 1.5-fold (0.19 log units) below what was measured; low and high end bracket the measured number.
By their numbers in this assay, from the lowest: compounds 1 and 4 (each within the scatter of the next); then compound 2. At a limit, above all of these: compound 3.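

In this assay, the aromatic carbon that carries chloro in compound 1 proves responsive to a second, quite different substituent: cyano at this place gives a 4.8-fold lower number from compound 2 to compound 4 (0.68 log units; beyond the scatter) and so shows that the lower number seen earlier does not belong to chloro alone. Exchanging one group directly for the other gives a 1.3-fold higher number from compound 1 to compound 4 (0.11 log units; within the scatter) and leaves compound 1 and compound 4 on level terms in this assay, even though cyano enters with 2 heavy atoms, a triple bond and a hydrogen-bond acceptor. The compounds shown offer no measurement that explains why either group lowers the number relative to hydrogen, or why the two end up so close.

On these data alone, whether other groups at this aromatic carbon, such as an amine, a methoxy group or a carboxylic acid, would also lower the number remains open, as does whether any of them would go beyond chloro and cyano. As far as these compounds go, it is equally open whether chloro or cyano would have a similar effect on the other aromatic carbons of the shared core.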